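A few compounds are considered here, and "the series" means these few. Any claim that something is new, unique, unknown or untested is made for them only; others in the source may bear on it.

Working notes on the series. Compound 1 `CC(=O)c1ccc(OCc2ccccc2C)cc1` gives 42.9% in an assay on isolated protein for inhibition of Amine oxidase [flavin-containing] A (Homo sapiens), read by Amplex Red, with a stated time of 15 min, tested at 100 uM; a higher number here means more inhibition at the concentration tested (going by the name of the read-out), a lower number less inhibition; compound 2 `CC(=O)c1ccc(OCc2cccc(C)c2)cc1` gives 32.3% in this assay. Compound 1 stands highest of the two numbers, with compound 2 nearest and beyond the scatter below it. Compound 3 `CC(=O)c1ccc(OCc2ccccc2[N+](=O)[O-])cc1` differs from compound 1 by nitro in place of methyl on an aromatic carbon. Among the compounds with values here, no measured pair shows this change, so the step is uncertain; a small downward shift is expected, as a number 7.9 percentage points lower from compound 1 to compound 3 (within the scatter), since only compound 1 with 42.9% anchors the estimate. Compound 3 is thus expected to give about 35% in this assay, within a range from 10% to 60%.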

Compound 3, a percentage reported as inhibition, at one concentration (the size of the read-out at that concentration, not a potency): 34%
Estimate against measurement, compound 3: 1 percentage points above; low and high end bracket the measured number.
By their numbers in this assay, from the lowest: compounds 2, 3 and 1 (each within the scatter of the next, the first and the last beyond it).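

In this assay, nitro in place of methyl on an aromatic carbon, ortho to a large group, gives a number 8.9 percentage points lower from compound 1 to compound 3 (within the scatter) for this change. Within the data shown here, this position thus takes nitro, with its 3 heavy atoms and 2 hydrogen-bond acceptors, in place of methyl without a step beyond the scatter, something the earlier compounds could not show. Nothing at hand explains how the two groups compare here. On these data alone, whether an amine or a carboxylic acid at this position would stay within the scatter of compound 1 remains open. Also open, as far as these compounds go, is whether nitro in place of the methyl of compound 2 gives a similar step.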